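Alkyl growth on the amine nitrogen of compound 2

The source may report more compounds than this note shows. Statements on the series, on what has been measured and on what is new or still open speak of the compounds shown alone.

Compound 1 `CC1(C)C(=O)NC(c2ccc(N)cc2)c2ccccc21` gives 20 mg/kg in a functional assay on the whole organism with Mus musculus as the target, in the maximal electroshock model, with a stated time of 3 h; a lower number here means that less compound is needed, a higher number that more compound is needed for the effect. Compound 2 `CNCC(=O)Nc1ccc(C2NC(=O)C(C)(C)c3ccccc32)cc1` gives 25 mg/kg, the higher of the two numbers, though a 1.3-fold higher number from compound 1 to compound 2 (0.10 log units; within the scatter). Compound 3 `CC(C)NCC(=O)Nc1ccc(C2NC(=O)C(C)(C)c3ccccc32)cc1` carries the change (isopropyl in place of methyl on an amine nitrogen). Within the data shown here, no measured step alters this amine substituent; the only step known, at the aromatic nitrogen, was within the scatter, so nothing points to a shift beyond it here. Compound 3 is therefore expected to give about 27 mg/kg, between 12 mg/kg and 60 mg/kg, meaning an expected 1.1-fold higher number from compound 2 to compound 3 (0.03 log units; within the scatter).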

Compound 3, dose for half-maximal effect: 27 mg/kg
The estimate for compound 3 equals the measured number at the digits printed; measured number inside the range.
By their numbers in this assay, from the lowest: compounds 1, 2 and 3 (each within the scatter of the next).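

In this assay, among these compounds, the step of a 1.1-fold higher number from compound 2 to compound 3 (0.03 log units; within the scatter) is the first reading of a change on the amine nitrogen itself: isopropyl in place of methyl, with two more carbons, stays within the scatter. The full group read against the free aromatic amine, a 1.4-fold higher number from compound 1 to compound 3 (0.13 log units; within the scatter), also stays within the scatter, so this position has so far tolerated both alkyl groups. No evidence on the cause of this flat result is available.

Open, from the compounds shown here alone, is whether a longer chain, a cyclohexyl group or a carboxylic acid on this amine nitrogen would move the number beyond the scatter.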